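The compounds below may be only part of what the source reports. "The series", "measured", "known", "first", "only" and "open" are said of these compounds alone.

Working notes on the step from compound 2 to compound 4.

Compound 2 `Cc1ccc(-n2cnc3cnc(-c4ccc(F)cc4C)cc32)cc1` gives 140 nM in a functional assay on HL-60 cells (Homo sapiens) for activation, read by flow cytometry, with a stated time of 4 days; on this read-out higher numbers stand for an effect only at larger amounts of compound and lower numbers for an effect already at smaller amounts. Within the data shown here, of the two numbers known in this assay, compound 2 stands highest; the nearest is compound 1 `CCOc1ccc(-n2cnc3cnc(-c4ccc(F)cc4C)cc32)cc1`, which in this assay gives 19 nM, the gap being a 7.4-fold higher number from compound 1 to compound 2 (0.87 log units; beyond the scatter) for methyl in place of ethoxy on an aromatic carbon. Compound 3 `Cc1cc(F)ccc1-c1cc2c(cn1)ncn2-c1ccc(S(C)(=O)=O)cc1` returns only a limit, > 30000 nM, in this assay. The steps of an at least 1500-fold higher number from compound 1 to compound 3 (3.19 log units; beyond the scatter) and an at least 210-fold higher number from compound 2 to compound 3 (2.33 log units; beyond the scatter) are the large ones of the set and run into (the limit of > 30000 nM in this assay, at which 1 of the 3 values shown sits).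

Compound 4 `COc1ncc(-n2cnc3cnc(-c4ccc(F)cc4C)cc32)cn1` is not yet measured. The change from compound 2 is 2-methoxypyrimidin-5-yl in place of 4-methylphenyl on an aromatic nitrogen. Among the measured compounds shown here, two measured steps bear on it. The entering ring carries methoxy, and the ethoxy of compound 1 sits at the low end, so the step of a 7.4-fold higher number from compound 1 to compound 2 (0.87 log units; beyond the scatter) read backwards points to a lower number. The ring itself also changes, and the only other substituent variation at that position, methylsulfonyl, gave an at least 210-fold higher number from compound 2 to compound 3 (2.33 log units; beyond the scatter); the three measured compounds do not show which of these two outcomes a ring with 2 hetero atoms follows. The expected step is therefore a modest one, a 1.6-fold lower number from compound 2 to compound 4 (0.19 log units; within the scatter), with a wide range on either side. Compound 4 is estimated at 90 nM in this assay, between 15 nM and 900 nM.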

Compound 4, half-maximal effective concentration: 2900 nM
Compound 4: middle estimate off by 32-fold (1.51 log units), on the low side, outside the stated range (above it).
By their numbers in this assay, from the lowest: compound 1; then compound 2; then compound 4. At a limit, above all of these: compound 3.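

In this assay, replacing 4-methylphenyl on the aromatic nitrogen with 2-methoxypyrimidin-5-yl gives a 21-fold higher number from compound 2 to compound 4 (1.32 log units; beyond the scatter), so this position is sensitive to a change of the ring itself and not only to a change of substituent on a ring of carbon only. Compound 1 and compound 2 had shown only how the number moves with the group on such a carbon ring, and a methoxy group on the entering ring does not by itself keep the number low here, as compound 4 shows. The compounds shown give no measured cause for this step.

On these data alone, the step changes the ring and its substituent at once, so it remains open how much of the rise belongs to the two ring nitrogens and how much to the methoxy group; 4-methoxyphenyl and an unsubstituted pyrimidin-5-yl would separate the two. Also open, as far as these compounds go, is how the 2-substituted pyrimidin-5-yl ring reads with an amine or a longer alkoxy chain in place of the methoxy group.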